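The source may report more compounds than this note shows. Statements on the series, on what has been measured and on what is new or still open speak of the compounds shown alone.

Compound 1, `NC1CCC(Nc2nc(NCc3ccc(Br)cc3)c3ncn(C4CCCC4)c3n2)CC1`: in a functional assay on HeLa cells (Homo sapiens) for inhibition, with a stated time of 72 h (on this read-out higher numbers stand for weaker inhibition and lower numbers for stronger inhibition), compound 1 gives 1510 nM.
Compound 2, `CC(C)(O)CNc1nc(NCc2ccc(-c3ccco3)cc2)c2ncn(C3CCCC3)c2n1`: in this assay compound 2 gives 14800 nM.
Compound 3, `CC(C)(O)CNc1nc(NCc2ccc(-c3ccco3)nc2)c2ncn(C3CCCC3)c2n1`: in this assay compound 3 gives 667 nM.

Among these three numbers compound 1 stands second highest. Its nearest neighbour is compound 3, whose number is lower by a margin beyond the scatter, and its furthest is compound 2, whose number is higher by a wider margin. Within the data shown here, the only step measured between compounds that differ in one place is a 22-fold lower number from compound 2 to compound 3 (1.35 log units; beyond the scatter), and that step concerns the aromatic ring on the saturated chain carbon bound to a nitrogen on an aromatic ring in a pair of compounds that otherwise share nothing with the change considered here.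

Compound 4, `NC1CCC(Nc2nc(NCc3cc(Cl)ccc3O)c3ncn(C4CCCC4)c3n2)CC1`, differs from compound 1 by 5-chloro-2-hydroxyphenyl in place of 4-bromophenyl on a saturated chain carbon bound to a nitrogen on an aromatic ring. Among the measured compounds shown here, no measured step covers this change, so there is no direct guide to its direction; the step from compound 2 to compound 3 shows only that a change on that ring can shift the number strongly. With nothing comparable to lean on, the step of a 1.0-fold lower number from compound 1 to compound 4 (0.00 log units; within the scatter) is expected to be small, within the scatter or close to it, in either direction. Compound 4 is therefore estimated at 1500 nM, with a range from 400 nM to 6000 nM.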

Compound 4, half-maximal inhibitory concentration: 750 nM
For compound 4 the middle estimate is 2.0-fold (0.30 log units) above the measured one, and the stated range covers the measured number.
By their numbers in this assay, from the lowest: compounds 3, 4 and 1 (each within the scatter of the next, the first and the last beyond it); then compound 2.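

In this assay, placing 5-chloro-2-hydroxyphenyl in place of 4-bromophenyl on a saturated chain carbon bound to a nitrogen on an aromatic ring gives a 2.0-fold lower number from compound 1 to compound 4 (0.30 log units; within the scatter), so the two compounds cannot be told apart on this read-out. Among these compounds, the earlier compounds showed only that a change on this ring can carry a large step, as in a 22-fold lower number from compound 2 to compound 3 (1.35 log units; beyond the scatter); this pair adds a case in which a ring with a hydroxy group and a chlorine instead of a bromine stays level with its parent, so a change at this place need not shift the number strongly. Nothing at hand explains why these two steps differ so much in size.

As far as these compounds go, the hydroxy group and the chlorine enter together, so the share of each remains unknown, and a plain 2-hydroxyphenyl, a 4-chlorophenyl or a methoxy group in place of the hydroxy would be needed to separate them. From the compounds shown here alone, it also remains open how 6-(furan-2-yl)pyridin-3-yl would read at this place on the core of compound 1, with its amine-bearing ring in place of the hydroxylated chain of compound 3.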